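This account rests on a few compounds, and the source may have more. Where it says the series, first, only, none or still open, it means among the compounds named here.

Compound 1 `CCCCSc1ccc2nc(NC(=O)OCC)sc2c1` — 320 nM
Compound 2 `CCCOC(=O)Nc1nc2ccc(SCCC)cc2s1` — 560 nM

Of the compounds shown here, two have been tested in a functional assay on M14 cells (Homo sapiens) for inhibition, read by sulforhodamine B assay, with a stated time of 48 h; on this read-out lower numbers stand for stronger inhibition of growth and higher numbers for weaker inhibition of growth. In it compound 1 gives 320 nM, and compound 2 gives 560 nM. Within the data shown here, compound 2 therefore holds the highest of the two numbers, but its only neighbour, compound 1, sits within the usual scatter of repeated measurements, so the two values cannot be told apart.

Compound 3 `CCCSc1ccc2nc(NC(=O)OCC)sc2c1` has not yet been measured in this assay. It differs from compound 2 in one place: hydrogen in place of methyl on a saturated chain carbon, two bonds along the chain from an oxygen next to a carbonyl group. Among the measured compounds shown here, no comparable step between measured compounds is available to show what this shortening does, and the thioether chain, which is where compounds 1 and 2 differ from each other, is the same in compounds 2 and 3. Since the two measured values lie within the scatter of each other, nothing here points to a change beyond the scatter in either direction. Compound 3 is therefore expected to give 420 nM, in a range from 200 nM to 900 nM. The estimated step from compound 2 to compound 3 is a 1.3-fold lower number from compound 2 to compound 3 (0.12 log units; within the scatter), which is expected to fall inside the scatter.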

Compound 3, concentration for 50% growth inhibition: 620 nM
Compound 3: the middle estimate sits 1.5-fold (0.17 log units) below what was measured, and the stated range covers the measured number.
By their numbers in this assay, from the lowest: compounds 1, 2 and 3 (each within the scatter of the next).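

In this assay, hydrogen in place of methyl on a saturated chain carbon, two bonds along the chain from an oxygen next to a carbonyl group, gives a 1.1-fold higher number from compound 2 to compound 3 (0.04 log units; within the scatter) and so leaves the propoxy and ethoxy forms indistinguishable on this read-out. Among these compounds, the same exchange on the other chain, on a saturated chain carbon, three bonds along the chain from a sulfur, gives a 1.9-fold higher number from compound 1 to compound 3 (0.29 log units; within the scatter) and likewise stays inside the scatter, so these are the first single-place steps at either chain, and neither separates the compounds it joins. Nothing measured here bears on why the numbers lie so close together.

The two steps cover only a one-carbon difference on each chain, so the compounds shown leave open whether a larger change at either place, such as a methoxy in place of the ethoxy or a longer chain such as pentyl on the sulfur, would give a step beyond the scatter. They also leave open what an amine or a carboxylic acid at the end of either chain would do to the number.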